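Methoxy added to the pendant phenyl of compound 3

The source may report more compounds than this note shows. Statements on the series, on what has been measured and on what is new or still open speak of the compounds shown alone.

Compound 1 `COc1cc(-n2ncnc2-c2cccc([N+](=O)[O-])c2)cc(OC)c1OC`, compound 2 `COc1cc(-c2ncnn2-c2cccc(N)c2)cc(OC)c1OC` and compound 3 `COc1cc(-c2ncnn2-c2ccccc2)cc(OC)c1OC` share one core. In a functional assay on K562 cells (Homo sapiens) for antiproliferative activity, read by MTT assay, with a stated time of 72 h (on this read-out higher numbers stand for weaker inhibition and lower numbers for stronger inhibition), compound 1 gives only a limit, > 10000 nM. Compound 2 likewise stops at a limit in this assay, > 10000 nM. Compound 3 also reaches only a limit, > 10000 nM. Among the compounds with values here, the single step between measured compounds, a step that the two limits leave unreadable from compound 2 to compound 3, hydrogen in place of amino on an aromatic carbon, cannot be sized since (the limit of > 10000 nM in this assay, at which 3 of the 3 values shown sit). Compound 4 `COc1ccc(-n2ncnc2-c2cc(OC)c(OC)c(OC)c2)cc1` differs from compound 3 by methoxy in place of hydrogen on an aromatic carbon, on an aromatic carbon of a six-membered aromatic ring of carbon only, para to a large group. Within the data shown here, no measured step bears on this change. Compound 4 is expected to stay at the limit, estimated at 12000 nM (range 6000 nM to 30000 nM). The expected step that the limit leaves unreadable from compound 3 to compound 4 is estimated to be small.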

Compound 4, half-maximal inhibitory concentration: 3600 nM
Estimate against measurement, compound 4: 3.3-fold (0.52 log units) above; the measured number lies below the stated range.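

Methoxy on the aromatic carbon para to a large group is the first change here to move the series off the limit in this assay, giving an at least 2.7-fold lower number from compound 3 to compound 4 (0.44 log units; beyond the scatter). Read against the amino compound, 4-methoxyphenyl in place of 3-aminophenyl on an aromatic nitrogen gives an at least 2.7-fold lower number from compound 2 to compound 4 (0.44 log units; beyond the scatter). Both steps are bounds and not sizes, since each starts from a compound held at the limit: the limit of > 10000 nM in this assay, at which 3 of the 4 values shown sit.

As far as these compounds go, whether ethoxy, hydroxy or chlorine on that carbon would carry the same step stays open. From the compounds shown here alone, the true size of both steps, and the effect of methoxy on another carbon of the pendant phenyl, also stay open.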